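Vinyl to ethyl on the shared core

The source may hold more compounds than are shown below. What is called first, only, known or untested is meant among the compounds shown, and "the series" means these compounds.

In a functional assay on P388 cells (Mus musculus) for cytotoxicity (on this read-out lower numbers stand for stronger inhibition and higher numbers for weaker inhibition), compound 1 `COC(=O)C[C@@H]1NC(=O)[C@@H](C)NC(=O)[C@@H]2Cc3ccc(OC)c(c3)Oc3ccc(cc3)C[C@@H](C(=O)N2C)N(C)C(=O)[C@H](C)NC(=O)[C@H](Cc2ccc(OC)cc2)N(C)C1=O` gives 41.7 nM, compound 2 `COc1ccc(C[C@H]2C(=O)N[C@@H](C)C(=O)N(C)[C@H]3Cc4ccc(cc4)Oc4cc(ccc4OC)C[C@@H](C(=O)N[C@H](C)C(=O)N[C@@H](CS)C(=O)N2C)N(C)C3=O)cc1` gives 363 nM and compound 3 `C=CC[C@@H]1NC(=O)[C@@H](C)NC(=O)[C@@H]2Cc3ccc(OC)c(c3)Oc3ccc(cc3)C[C@@H](C(=O)N2C)N(C)C(=O)[C@H](C)NC(=O)[C@H](Cc2ccc(OC)cc2)N(C)C1=O` gives 38.9 nM. Two steps fix the standing of compound 3 on these numbers: a 1.1-fold lower number from compound 1 to compound 3 (0.03 log units; within the scatter), and a 9.3-fold lower number from compound 2 to compound 3 (0.97 log units; beyond the scatter). It therefore shares the low end of the series with one partner and lies clearly apart from the sulfanyl member.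

The next analogue is compound 4 `CCC[C@@H]1NC(=O)[C@@H](C)NC(=O)[C@@H]2Cc3ccc(OC)c(c3)Oc3ccc(cc3)C[C@@H](C(=O)N2C)N(C)C(=O)[C@H](C)NC(=O)[C@H](Cc2ccc(OC)cc2)N(C)C1=O`. It carries ethyl in place of vinyl on a saturated chain carbon bound to a saturated ring carbon, which, cut one bond further out, reads allyl to propyl (ethyl in place of vinyl on a saturated chain carbon bound to a saturated ring carbon). The double bond is lost, and the shared core stays the same.

All three measured steps changed this same place. The exchange of methoxycarbonyl for vinyl left the number unmoved, a 1.1-fold lower number from compound 1 to compound 3 (0.03 log units; within the scatter). Only sulfanyl stands apart, an 8.7-fold higher number from compound 1 to compound 2 (0.94 log units; beyond the scatter). Among the compounds with values here, with just three compounds this is thin evidence, and no measured step shows a saturated chain at this place.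

In this assay, no step beyond the scatter is expected here, and the estimated step is a 1.2-fold higher number from compound 3 to compound 4 (0.06 log units; within the scatter). The estimate for compound 4 is 45 nM, with an expected range of 18 nM to 110 nM.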

Compound 4, half-maximal inhibitory concentration: 13.8 nM
Compound 4: middle estimate off by 3.3-fold (0.51 log units), on the high side; measured number below the stated range.
By their numbers in this assay, from the lowest: compound 4; then compounds 3 and 1 (each within the scatter of the next); then compound 2.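

In this assay, this position on a saturated chain carbon bound to a saturated ring carbon responds to a change that leaves the heavy-atom count untouched: a 2.8-fold lower number from compound 3 to compound 4 (0.45 log units; beyond the scatter) accompanies the exchange of allyl for propyl, the lost double bond being the only counted difference between the two groups. Compounds 1 and 3 could not be separated on their numbers, but the propyl chain separates from both, with a 3.0-fold lower number from compound 1 to compound 4 (0.48 log units; beyond the scatter) for ethyl in place of methoxycarbonyl, and the gap to the sulfanyl member widens to a 26-fold lower number from compound 2 to compound 4 (1.42 log units; beyond the scatter) for ethyl in place of sulfanyl. Compound 4 therefore holds the lowest number of the four, with its steps to all three others beyond the scatter, and nothing available here bears on why the saturated chain gives that number.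

The compounds shown leave open whether a longer chain such as butyl would lower the number further or reverse this step. Also open, going by these compounds, is how an amine or a carboxylic acid at this place would compare with the propyl chain of compound 4 on the shared core.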